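The source may hold more compounds than are shown below. What is called first, only, known or untested is meant among the compounds shown, and "the series" means these compounds.

Working notes on the cyclopropane series in a functional assay on AP1 cells for inhibition of sodium/hydrogen exchanger 1 (Homo sapiens); on this read-out lower numbers stand for stronger inhibition and higher numbers for weaker inhibition.

Compound 2 `CC1(C)[C@H](c2cc(Cl)cc(Cl)c2)[C@H]1c1c[nH]c(N)n1` gives 180 nM and stands at the lowest number among the two values reported as numbers. The nearest is compound 3 `CC1(C)[C@H](c2cc(Cl)cc(Cl)c2)[C@H]1c1cc(N)nc(N)n1`, which gives 3600 nM; the gap from compound 2 to compound 3 lies beyond the usual scatter. Compound 1 `CC1(C)[C@H](c2c[nH]cn2)[C@H]1c1cccc2c1CCO2` returns only a limit, > 30000 nM, and no number; this is the limit described as the limit of > 30000 nM in this assay, at which 1 of the 3 values shown sits.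

The step under consideration goes from compound 2 to compound 4 `Cc1[nH]cnc1[C@@H]1[C@@H](c2cc(Cl)cc(Cl)c2)C1(C)C`, not yet measured. The change is 5-methyl-1H-imidazol-4-yl in place of 2-amino-1H-imidazol-4-yl on a saturated ring carbon, in words: 5-methyl-1H-imidazol-4-yl in place of 2-amino-1H-imidazol-4-yl on a saturated ring carbon. For the measured compounds named here, no measured pair isolates this change, so its size can only be expected. Going by the values given here, compound 3, which also carries a ring with amino groups, sits well above compound 2, and compound 1, which carries an imidazole without the amino group on a different partner, reaches only the limit; neither pair separates the single change cleanly.

Compound 4 is therefore expected to be weaker than compound 2, with the expected step of a 17-fold higher number from compound 2 to compound 4 (1.22 log units; beyond the scatter). The estimate for compound 4 is 3000 nM, within the range 600 nM to 15000 nM.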

Compound 4, half-maximal inhibitory concentration: 950 nM
Estimate against measurement, compound 4: 3.2-fold (0.50 log units) above, within the range that was stated.
By their numbers in this assay, from the lowest: compound 2; then compound 4; then compound 3. At a limit, above all of these: compound 1.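

In this assay, for the compounds shown here, the pair of compound 2 and compound 4 isolates 5-methyl-1H-imidazol-4-yl in place of 2-amino-1H-imidazol-4-yl on a saturated ring carbon of the three-membered ring, a change that no earlier pair could read: a 5.3-fold higher number from compound 2 to compound 4 (0.72 log units; beyond the scatter) is a modest step. The result also shows that the 2-amino group is not needed for a measurable number at this position, as compound 4, which lacks it, gives 950 nM. The exchange removes a hydrogen-bond donor and a hydrogen-bond acceptor by the counts for the two groups and also brings in a methyl group, but nothing measured here bears on why the number rises.

Going by these compounds alone, the single step therefore leaves open how much of it belongs to the loss of the amine and how much to the gain of the methyl group, a question that the plain 1H-imidazol-4-yl group or 2-amino-5-methyl-1H-imidazol-4-yl on the core of compound 2 would address. Also open, from the compounds shown here alone, is how a larger group at the same place, such as a methylamino or ethyl group, would compare with the amine in compound 2.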